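Ring Size at the Thiocarbonyl and Antiproliferative Potency

The source may report more compounds than this note shows. Statements on the series, on what has been measured and on what is new or still open speak of the compounds shown alone.

Three compounds have been measured in a functional assay on MDA-MB-435S cells (Homo sapiens) for antiproliferative activity, read by MTT assay, with a stated time of 72 h; a lower number here means a stronger inhibitor, a higher number a weaker inhibitor:

compound 1, `O=c1c(Cl)c(CSC(=S)N2CCCCC2)oc2ccccc12`, gives 770 nM
compound 2, `O=c1c(CSC(=S)N2CCCCC2)coc2cc(Cl)ccc12`, gives 240 nM
compound 3, `O=c1c(Cl)c(CSC(=S)N2CCCC2)oc2ccccc12`, gives 1800 nM

Compound 2 stands lowest of the three in this assay, with compound 1 nearest and compound 3 furthest. Compound 1 and compound 2 are built from the same atoms joined differently, and the difference between their two cores is not broken down here; the two values alone show that compound 2 is the stronger inhibitor.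

Within the core of compound 1, a single change has been measured: pyrrolidin-1-yl in place of piperidin-1-yl on a thiocarbonyl carbon. This gave a 2.3-fold higher number from compound 1 to compound 3 (0.37 log units; beyond the scatter).

Compound 4, `O=c1c(CSC(=S)N2CCCC2)coc2cc(Cl)ccc12`, is not yet measured. It carries the same change on the core of compound 2: pyrrolidin-1-yl in place of piperidin-1-yl on a thiocarbonyl carbon. The place of the change is described in the same words for both pairs, so this is the same change, not merely the same kind.

On the core of compound 2 this step is expected to come out as a 2.3-fold higher number from compound 2 to compound 4 (0.36 log units; beyond the scatter), set beside the measured 2.3-fold higher number from compound 1 to compound 3 (0.37 log units; beyond the scatter). Within the data shown here, the expectation rests on the one measured instance of the change, because compound 2 gives 240 nM and the same change already gave a 2.3-fold higher number from compound 1 to compound 3 (0.37 log units; beyond the scatter). Among the measured compounds shown here, with only one prior example, the range is kept wide. Compound 4 is therefore expected to give about 550 nM in this assay, most likely between 250 nM and 1200 nM.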

Compound 4, half-maximal inhibitory concentration: 6400 nM
The estimate for compound 4 lay 12-fold (1.07 log units) below the measured number, outside the stated range (above it).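

In this assay, putting pyrrolidin-1-yl in place of piperidin-1-yl on a thiocarbonyl carbon gave a 27-fold higher number from compound 2 to compound 4 (1.43 log units; beyond the scatter), which makes this the large step of the pair. The change moved the number in the same direction on both cores, so the direction carried over from one core to the other, but its size did not: the same change on two cores in this assay, a 2.3-fold higher number (0.37 log units; beyond the scatter) from compound 1 to compound 3 and a 27-fold higher number (1.43 log units; beyond the scatter) from compound 2 to compound 4, 11-fold (1.06 log units) apart, beyond the scatter of two such steps

With one pair on each core, these results do not show which feature of the two cores sets the size of the step, nor how large the step would be on a third core, so the size measured on one core cannot be taken as a guide to the other in this series.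

The compounds shown leave open how each core responds to other amines on the thiocarbonyl carbon, such as morpholine, azepane or the open-chain diethylamine, and whether the gap between the cores would persist with those groups. They also leave open whether the two cores would keep the same gap in the size of this step in a cell line other than the one tested here.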